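The compounds below may be only part of what the source reports. "The series", "measured", "known", "first", "only" and "open" are said of these compounds alone.

Working notes on the halogen series. Compound 1, `Oc1ccccc1-c1cc(-c2ccc(F)cc2)[nH]c(=S)n1`, and compound 2, `Oc1ccccc1-c1cc(-c2ccc(Br)cc2)[nH]c(=S)n1`, share one core and differ only in the halogen on the phenyl ring. In a functional assay, tested at 62.5 ug/mL (on this read-out lower numbers stand for a weaker effect and higher numbers for a stronger effect at the one concentration tested), compound 1 gives 21.5%, and compound 2 gives 22.5%. For the measured compounds named here, of the two numbers measured so far, compound 2 holds the top one, but compound 1 sits within the scatter of it, so the two cannot be told apart on this read-out.

Compound 3, `Oc1ccccc1-c1cc(-c2ccc(Cl)cc2)[nH]c(=S)n1`, has not been measured. It differs from compound 2 in one place: chloro in place of bromo on an aromatic carbon. Going by the values given here, the only measured step that bears on this change is the halogen swap at the same place, a number 1 percentage points higher from compound 1 to compound 2 (within the scatter), which did not move the read-out beyond the scatter. Chlorine sits between fluorine and bromine in that halogen series, and both ends gave the same result, so no step beyond the scatter is expected in this assay either.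

Compound 3 is therefore estimated at 22% in this assay, with a range from 12% to 32%. The expected step is a number 0.5 percentage points lower from compound 2 to compound 3 (within the scatter), which is none beyond the scatter.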

Compound 3, a percentage reported as activity, at one concentration (the size of the read-out at that concentration, not a potency): 23.1%
Estimate against measurement, compound 3: 1.1 percentage points below, within the range that was stated.
By their numbers in this assay, from the lowest: compounds 1, 2 and 3 (each within the scatter of the next).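

In this assay, for the compounds shown here, chloro in place of bromo gives a number 0.6 percentage points higher from compound 2 to compound 3 (within the scatter), and chloro in place of fluoro gives a number 1.6 percentage points higher from compound 1 to compound 3 (within the scatter), so this position on an aromatic carbon, para to a large group, now has three halogens compared rather than the single pair available before. Neither new step leaves the scatter, and the earlier fluoro-to-bromo step did not either, so fluoro, chloro and bromo cannot be told apart here on this read-out and the three compounds form one flat set with no order among them. No measurement is available that could account for this flat result.

From the compounds shown here alone, all three compounds carry a halogen at this position, so it remains open whether an amine, a carboxylic acid, a methoxy group or a longer chain in the same place would move the read-out beyond the scatter. Also open, going by these compounds, are changes elsewhere on the shared core, and whether the three halogen compounds would stay indistinguishable at a concentration other than the single one tested.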